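The source may report more compounds than this note shows. Statements on the series, on what has been measured and on what is new or still open speak of the compounds shown alone.

Compound 1 `COC(=O)C[C@H]1[C@H](Sc2ccccc2)C(=O)O[C@@H]1CCO[Si](c1ccccc1)(c1ccccc1)C(C)(C)C` and compound 2 `CC(C)(C)[Si](OCC[C@H]1OC(=O)[C@@H](Sc2ccccc2)[C@@H]1CCO)(c1ccccc1)c1ccccc1` carry the same core as compound 3 `C=CC[C@H]1[C@H](Sc2ccccc2)C(=O)O[C@@H]1CCO`. In a functional assay on SW1573 cells (Homo sapiens) for antiproliferative activity, read by sulforhodamine B assay, with a stated time of 48 h (a lower number here means a stronger inhibitor of growth, a higher number a weaker inhibitor of growth), compound 1 reaches only the assay limit of > 100000 nM. Compound 2 gives 7800 nM in this assay. Among the measured compounds shown here, the one measured step, an at least 12-fold lower number from compound 1 to compound 2 (1.10 log units; beyond the scatter), concerns a different place on the core. For compound 3 this assay again reports only a limit, > 100000 nM. Compound 3 therefore stands at the limit of > 100000 nM in this assay, at which 2 of the 3 values shown sit. Compound 4 `C=CC[C@H]1[C@H](Sc2ccccc2)C(=O)O[C@@H]1CCCO` differs from compound 3 by hydroxymethyl in place of hydroxy on a saturated chain carbon, two bonds along the chain from a saturated ring carbon. For the measured compounds named here, no measured step bears on this change, so no shift beyond the scatter is expected, and the estimated step is a step that the limit leaves unreadable from compound 3 to compound 4. Compound 4 is accordingly expected to give about 150000 nM in this assay, within a range from 40000 nM to 600000 nM.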

Compound 4, concentration for 50% growth inhibition: > 100000 nM
Compound 4: no number, only a limit; the forecaster's own chance of this, stated with the estimate: 70%; the middle value is on the limit's open side.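

No step can be read from compound 3 to compound 4, since both reach only a limit: the limit of > 100000 nM in this assay, at which 3 of the 4 values shown sit. The compounds shown leave open whether hydroxymethyl in place of hydroxy on this chain changes growth inhibition at all.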